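Swapping an Allyloxy Group for Benzamido on a Cyclopentenone

This account rests on a few compounds, and the source may have more. Where it says the series, first, only, none or still open, it means among the compounds named here.

Compound 2, with structure `C=CCOc1cc(C2=C(c3cc(OC)c(OC)c(OC)c3)C(=O)C(O)C2)ccc1OC`, was tested in an ADME assay on HT-29 cells (Homo sapiens) for cytotoxicity, read by MTT assay, with a stated time of 72 h; on this read-out higher numbers stand for weaker inhibition and lower numbers for stronger inhibition. In this assay compound 2 gives > 100 ug/mL, which is a limit of the assay rather than a number. Compound 1 `COc1cc(C2=C(c3cc(C)c(OC)c(C)c3)C(O)CC2=O)cc(OC)c1OC` also gives > 100 ug/mL, again a limit. Compound 3 `COc1ccc(C2=C(c3cc(OC)c(OC)c(OC)c3)CC(O)C2=O)cc1N` gives < 1 ug/mL, a limit at the other end. Compound 4 `COc1ccc(C2=C(c3cc(OC)c(OC)c(OC)c3)C(=O)C(O)C2)cc1NC(=O)c1ccccc1` has not yet been measured; it differs from compound 2 by benzamido in place of allyloxy on an aromatic carbon. Among the compounds with values here, no pair of measured compounds differing in one place is available, so the size of this step cannot be read from the data. Still, stronger inhibition is expected for compound 4 than for compound 2, an estimated step of an at least 5.0-fold lower number from compound 2 to compound 4 (0.69 log units; beyond the scatter). Compound 4 is estimated at 20 ug/mL, within 2 ug/mL to 100 ug/mL.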

Compound 4, half-maximal inhibitory concentration: > 100 ug/mL
Compound 4 was reported as a limit; the forecaster's own chance of this, stated with the estimate: 35%; middle value at least 5.0-fold (0.69 log units) away from the limit.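

Within the data shown here, no step from compound 2 to compound 4 can be read: both stand at the same limit of this assay, not at a number. The compounds shown leave open whether benzamido in place of allyloxy changes inhibition at all.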